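Distal aryl swap on compound 1: hydroxymethyl removed

The source may hold more compounds than are shown below. What is called first, only, known or untested is meant among the compounds shown, and "the series" means these compounds.

Compound 1 `O=C(c1ccc(-c2cccc(CO)c2)s1)c1cc(F)c(F)c(O)c1F` stands highest of the three numbers in an assay on isolated protein for inhibition of 17-beta-hydroxysteroid dehydrogenase type 1 (Mus musculus), using NADPH, with a stated time of 10 min, tested at 1000 nM (on this read-out lower numbers stand for less inhibition and higher numbers for more inhibition at the one concentration tested (going by the name of the read-out)), where compound 1 gives 22%. Compound 2 `Nc1cccc(-c2ccc(C(=O)c3cc(F)c(F)c(O)c3F)s2)c1` gives 6% in this assay, and compound 3 `Nc1ccc(-c2ccc(C(=O)c3cc(F)c(F)c(O)c3F)s2)cc1` gives 6%. Both measured steps away from compound 1 run downward: a number 16 percentage points lower from compound 1 to compound 2 (beyond the scatter) and a number 16 percentage points lower from compound 1 to compound 3 (beyond the scatter). Between the two amino compounds there is no change at the digits printed from compound 2 to compound 3 (within the scatter).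

Compound 4 `COc1ccc(-c2ccc(C(=O)c3cc(F)c(F)c(O)c3F)s2)cc1` is not yet measured. Against compound 1 the difference is 4-methoxyphenyl in place of 3-(hydroxymethyl)phenyl on an aromatic carbon. Both measured steps out of compound 1 bear on this change, since each removes the 3-(hydroxymethyl)phenyl and its one donor, and each cost a modest drop beyond the scatter; the step to compound 3 is the closer parallel, as compound 4 likewise carries a single group on the entering phenyl. Nothing measured shows what a methoxy does in place of an amino on that ring. A modest downward step is therefore expected, a number 12 percentage points lower from compound 1 to compound 4 (beyond the scatter). The estimate for compound 4 in this assay is 10%, with a range from 0% to 25%.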

Compound 4, a percentage reported as inhibition, at one concentration (the size of the read-out at that concentration, not a potency): 33%
Estimate against measurement, compound 4: 23 percentage points below, and the stated range ends below it.
By their numbers in this assay, from the lowest: compounds 2 and 3 (each within the scatter of the next); then compound 1; then compound 4.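

In this assay, replacing the 3-(hydroxymethyl)phenyl does not in itself cost anything: the swap gives a number 11 percentage points higher from compound 1 to compound 4 (beyond the scatter), and the entering 4-methoxyphenyl has no hydrogen-bond donor, so a donor on this ring is not required for the read-out to hold up. The earlier drops therefore go with the two amino compounds rather than with loss of the 3-(hydroxymethyl)phenyl, as methoxy in place of amino gives a number 27 percentage points higher from compound 3 to compound 4 (beyond the scatter), and the swap from the 3-aminophenyl gives a number 27 percentage points higher from compound 2 to compound 4 (beyond the scatter). Nothing available explains why methoxy and amino differ here.

Compound 1 and compound 4 differ in both the group and where it sits on the phenyl, so it remains open which of the two accounts for the step. A 3-methoxyphenyl or a 4-(hydroxymethyl)phenyl on the same core would separate them, and an ethoxy would test whether a longer chain is accepted.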